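The source may hold more compounds than are shown below. What is called first, only, known or untested is meant among the compounds shown, and "the series" means these compounds.

Compounds measured so far:

Compound 1, `CN1CCC[C@@H]1Cn1nc(Cc2ccc(O)cc2)c2ccccc2c1=O` — 251 nM
Compound 2, `O=c1c2ccccc2c(Cc2ccc(Cl)cc2)nn1C1CCCN(Cc2ccc(OCCCN3CCCCCC3)cc2)CC1` — 100 nM
Compound 3, `CN1CCCC1CCn1nc(Cc2ccc(Cl)cc2)c2ccccc2c1=O` — 316 nM

All three were tested in an assay for binding affinity to Alpha-1A adrenergic receptor (Homo sapiens); on this read-out lower numbers stand for stronger inhibition and higher numbers for weaker inhibition. Compound 1 holds the second highest number of the three. Compound 3 sits nearest to it, and the gap between the two lies within the scatter of repeated measurements, so the two cannot be told apart on these numbers. Compound 2, with its longer side chain, gives a lower number than compound 1, and that gap lies beyond the scatter. Among the compounds with values here, no pair among the measured compounds differs in a single place, so no step size is known from the data themselves.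

Compound 4, `COc1cccc(Cc2nn(C[C@H]3CCCN3C)c(=O)c3ccccc23)c1`, has not yet been measured in this assay. It differs from compound 1 in one place: 3-methoxyphenyl in place of 4-hydroxyphenyl on a saturated chain carbon bound to an aromatic carbon. This change removes the hydroxyl hydrogen-bond donor and moves the oxygen substituent to another position on the ring, while the rest of the molecule, including the core and the methylpyrrolidinylmethyl group, stays unchanged. Since the hydroxyphenyl of compound 1 and the chlorophenyl of compound 3 give numbers within the scatter of one another, this part of the molecule does not appear to be sensitive to such changes in what is shown here, though only two compounds support that view.

For compound 4 a step of a 1.2-fold higher number from compound 1 to compound 4 (0.08 log units; within the scatter) is expected, that is, no change beyond the scatter. Compound 4 is estimated to give 300 nM in this assay, with a likely range from 120 nM to 800 nM.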

Compound 4, inhibition constant: 1580 nM
Estimate against measurement, compound 4: 5.3-fold (0.72 log units) below; measured number above the stated range.
By their numbers in this assay, from the lowest: compound 2; then compounds 1 and 3 (each within the scatter of the next); then compound 4.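

In this assay, replacing 4-hydroxyphenyl with 3-methoxyphenyl on a saturated chain carbon bound to an aromatic carbon gives a 6.3-fold higher number from compound 1 to compound 4 (0.80 log units; beyond the scatter), the first step read from a pair differing in one place, and it shows that this position is not indifferent to the group it carries. Within the data shown here, the single step bundles several differences: the hydrogen-bond donor count falls from 1 to 0, the oxygen substituent moves to another ring position, and the group gains a heavy atom, so the step cannot be divided among them. Nothing available here accounts for the size of the step.

On these data alone, whether the change in the oxygen substituent itself or its new ring position carries the step remains open; a methoxy group in the ring position of the hydroxyl of compound 1, or a hydroxyl in the ring position of the methoxy of compound 4, would separate the two. As far as these compounds go, how a plain phenyl with no substituent would read at this place, and whether the step would hold with a longer chain in place of the methylpyrrolidinylmethyl group, also remains unknown.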